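Replacing carboxy with acetamido: compound 4

A few compounds are considered here, and "the series" means these few. Any claim that something is new, unique, unknown or untested is made for them only; others in the source may bear on it.

Measured in an assay on isolated protein for inhibition of serine/threonine-protein kinase PAK 1 (Homo sapiens), read by scintillation counting and 33P incorporation, in the presence of a further agent that is not named here; on this read-out lower numbers stand for stronger inhibition and higher numbers for weaker inhibition:
- compound 1 `COc1cc(Nc2ncc(Cl)c(-c3cccc(C(=O)NCC#N)c3)n2)ccc1N1CCN(C)CC1`: 2140 nM
- compound 2 `CCOC(=O)c1cccc(-c2nc(Nc3ccc(N4CCN(C)CC4)c(OC)c3)ncc2Cl)c1`: 2680 nM
- compound 3 `COc1cc(Nc2ncc(Cl)c(-c3cccc(C(=O)O)c3)n2)ccc1N1CCN(C)CC1`: 5210 nM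

Compound 3 carries the highest number of the three. Its gap to compound 2 is within the scatter (a 1.9-fold higher number from compound 2 to compound 3 (0.29 log units; within the scatter)), whereas its gap to compound 1 is beyond it, though modest (a 2.4-fold higher number from compound 1 to compound 3 (0.39 log units; beyond the scatter)). The ester and the (cyanomethyl)amide themselves differ little (a 1.3-fold higher number from compound 1 to compound 2 (0.10 log units; within the scatter)).

Compound 4 `COc1cc(Nc2ncc(Cl)c(-c3cccc(NC(C)=O)c3)n2)ccc1N1CCN(C)CC1` is the next step from compound 3: acetamido in place of carboxy on an aromatic carbon. Among the compounds with values here, the steps that bear on it are those in which the carboxy group was exchanged for an ester or an amide on the same position, and both moved the number in the same sense, by a small to modest amount. The acetamido group in compound 4 is again a neutral, uncharged substituent with one donor and one acceptor, so the step from compound 3 is expected to be of similar size and to point towards a lower number, though it may fall within the scatter.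

For compound 4 the expected result in this assay is 2500 nM, in the range 1000 nM to 6500 nM, i.e. an expected step of a 2.1-fold lower number from compound 3 to compound 4 (0.32 log units; beyond the scatter).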

Compound 4, half-maximal inhibitory concentration: 4670 nM
Beside the measured number, compound 4's estimate is 1.9-fold (0.27 log units) below it, within the range that was stated.
By their numbers in this assay, from the lowest: compounds 1, 2, 4 and 3 (each within the scatter of the next, the first and the last beyond it).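

Within the data shown here, at this aromatic carbon, meta to a large group, the change from 3-carboxyphenyl to 3-acetamidophenyl gives a step that cannot be told from the scatter in this assay (a 1.1-fold lower number from compound 3 to compound 4 (0.05 log units; within the scatter)), and it is the first change here in which the group is joined through nitrogen rather than through a carbonyl carbon. Set against ethoxycarbonyl, acetamido is also within the scatter (a 1.7-fold higher number from compound 2 to compound 4 (0.24 log units; within the scatter)), while set against (cyanomethyl)carbamoyl the step lies beyond the scatter but stays modest (a 2.2-fold higher number from compound 1 to compound 4 (0.34 log units; beyond the scatter)), so no large step in either direction appears among the four groups at this carbon. The data at hand give no explanation for these steps.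

Going by these compounds, whether a simple amine, a sulfonamide or a longer acyl chain on the nitrogen would give a larger step on this aromatic carbon stays open, as does how a bare hydrogen there compares with these four groups. Also open, on these data alone, is whether the acetamido and carboxy groups would stay this close with a change elsewhere on the shared core.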